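One Methoxy Fewer: From Compound 2 to Compound 3

This account rests on a few compounds, and the source may have more. Where it says the series, first, only, none or still open, it means among the compounds named here.

Compound 1 `COc1ccc(-c2cc(/C=C/C(=O)c3ccc(N)cc3)[nH]n2)cc1`: 4920 nM in a functional assay on OVCAR-5 cells (Homo sapiens) for inhibition, read by sulforhodamine B assay, with a stated time of 48 h; a lower number here means a stronger inhibitor of growth, a higher number a weaker inhibitor of growth.
Compound 2 `COc1cc(-c2cc(/C=C/C(=O)c3ccc(N)cc3)[nH]n2)cc(OC)c1OC`: 3750 nM in this assay.

Compound 2 holds the lowest of the two numbers shown, but compound 1 sits within the usual scatter of it, so the two cannot be told apart. Compound 3 `COc1ccc(-c2cc(/C=C/C(=O)c3ccc(N)cc3)[nH]n2)cc1OC` differs from compound 2 by hydrogen in place of methoxy on an aromatic carbon. Within the data shown here, no step between measured compounds is available; the two values show only that one methoxy group and three give much the same number. For compound 3 the expected step is a 1.1-fold higher number from compound 2 to compound 3 (0.05 log units; within the scatter), nothing beyond the scatter. Compound 3 is estimated at 4200 nM, with a range from 2000 nM to 9000 nM.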

Compound 3, concentration for total growth inhibition: 7940 nM
For compound 3 the middle estimate is 1.9-fold (0.28 log units) below the measured one; the measured number falls inside the stated range.
By their numbers in this assay, from the lowest: compounds 2, 1 and 3 (each within the scatter of the next, the first and the last beyond it).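

In this assay, among these compounds, hydrogen in place of methoxy on this aromatic carbon, ortho to a methoxy group and meta to a large group, gives a 2.1-fold higher number from compound 2 to compound 3 (0.33 log units; beyond the scatter) and is the first step here to pass the scatter, though only modestly. The other change, methoxy in place of hydrogen on an aromatic carbon, gives a 1.6-fold higher number from compound 1 to compound 3 (0.21 log units; within the scatter) and so cannot be told from no change. Nothing measured here accounts for either step. Still open, from the compounds shown here alone, is how a hydroxy group, a fluorine atom or an ethoxy group on this aromatic carbon would read in this assay and whether the modest step would hold on another cell line.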